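A few compounds are considered here, and "the series" means these few. Any claim that something is new, unique, unknown or untested is made for them only; others in the source may bear on it.

Compound 3 `COc1cc(/C=C/C(=O)Nc2ccccc2)ccc1OCCCCCN(C)C` gives 1.61 in a physicochemical assay for lipophilicity, using the shake flask method, measured as octanol-water partition, at pH 7.4 (on this read-out lower numbers stand for lower lipophilicity and higher numbers for higher lipophilicity), the highest of the three numbers at hand, though its nearest neighbour compound 2 `CCN(CC)CCCCOc1ccc(/C=C/C(=O)Nc2ccccc2)cc1OC` with 1.59 and the furthest, compound 1 `COc1cc(/C=C/C(=O)Nc2ccccc2)ccc1OCCCN1CCCCC1` with 1.58, both sit within the scatter of it, so no order among the three can be claimed. The measured steps confirm this: a number 0.01 log units higher from compound 1 to compound 2 (within the scatter), a number 0.03 log units higher from compound 1 to compound 3 (within the scatter) and a number 0.02 log units higher from compound 2 to compound 3 (within the scatter). Each of these swaps one basic amine end group for another while the total size of the molecule stays about the same, and none of them moves this assay beyond the scatter.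

Compound 4 `COc1cc(/C=C/C(=O)Nc2ccccc2)ccc1OCCCCCCN1CCCC1` is the next step from compound 3. The change is (pyrrolidin-1-yl)methyl in place of dimethylamino on a saturated chain carbon, five bonds along the chain from an oxygen on an aromatic ring. Unlike the three measured steps, this exchange does not keep the molecule at the same size: the entering (pyrrolidin-1-yl)methyl carries more heavy atoms and a ring where the leaving dimethylamino had none, so the earlier steps, all within the scatter, do not directly cover it. Compound 4 is therefore expected to give a clearly higher number, with an estimated step of a number 0.89 log units higher from compound 3 to compound 4 (beyond the scatter). The estimate for compound 4 in this assay is 2.5, in a range from 1.9 to 3.1.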

Compound 4, partition coefficient: 1.76
Compound 4: the middle estimate sits 0.74 log units above what was measured; the whole stated range lies above it.
By their numbers in this assay, from the lowest: compounds 1, 2, 3 and 4 (each within the scatter of the next).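

In this assay the exchange at this position, on a saturated chain carbon five bonds along the chain from an oxygen on an aromatic ring, reads a number 0.15 log units higher from compound 3 to compound 4 (within the scatter) even though the entering (pyrrolidin-1-yl)methyl brings more heavy atoms and a five-membered non-aromatic ring, and the two wider comparisons read a number 0.17 log units higher from compound 2 to compound 4 (within the scatter) and a number 0.18 log units higher from compound 1 to compound 4 (within the scatter) as well. The earlier steps shown here covered only swaps of one amine end group for another at about the same size, whereas these show that a change in size of this kind also stays inside the scatter, so all four compounds remain without an order on this read-out. Nothing at hand bears on why this exchange stays within the scatter.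

On these data alone, whether a morpholin-4-yl end group, or a carboxylic acid in place of the amine, would move this assay beyond the scatter remains open. So does the outcome for a longer chain carrying the same pyrrolidin-1-yl ring, since the compounds shown do not tell how far such an extension could go before the number leaves the scatter of compound 3 and its neighbours.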